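Benzyl for dimethylaminophenoxy: carrying a solubility step across

A few compounds are considered here, and "the series" means these few. Any claim that something is new, unique, unknown or untested is made for them only; others in the source may bear on it.

Compound 1 `CN(C)c1cccc(Oc2ccc3c(NCCCNCc4ccco4)ccnc3c2)c1` and compound 2 `c1ccc(Cc2ccc3c(NCCCNCc4ccco4)ccnc3c2)cc1` differ by benzyl in place of 3-(dimethylamino)phenoxy on an aromatic carbon. In a physicochemical assay for solubility, with a stated time of 18 h, at pH 7.4 (a lower number here means a less soluble compound, a higher number a more soluble compound), compound 1 gives 14500 nM, and compound 2 gives 4200 nM, a step of a 3.5-fold lower number from compound 1 to compound 2 (0.54 log units; beyond the scatter). Compound 3 `COc1ccc(F)cc1CNCCCNc1ccnc2cc(Oc3cccc(N(C)C)c3)ccc12` differs from compound 1 in the core by 5-fluoro-2-methoxyphenyl in place of furan-2-yl on a saturated chain carbon bound to an amine nitrogen; in this assay compound 3 gives 14500 nM, so no change at the digits printed from compound 1 to compound 3 (within the scatter). Among the compounds with values here, compound 4 `COc1ccc(F)cc1CNCCCNc1ccnc2cc(Cc3ccccc3)ccc12` is not yet measured; it differs from compound 3 by benzyl in place of 3-(dimethylamino)phenoxy on an aromatic carbon, the same change at the same place as the one from compound 1 to compound 2. For compound 4 the expected step in this assay is a 3.5-fold lower number from compound 3 to compound 4 (0.54 log units; beyond the scatter), set beside the earlier 3.5-fold lower number from compound 1 to compound 2 (0.54 log units; beyond the scatter), and this expectation rests on that single earlier occurrence together with no change at the digits printed from compound 1 to compound 3 (within the scatter). Compound 4 is therefore estimated at 4200 nM, with a range from 1500 nM to 10000 nM.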

Compound 4, solubility: 4200 nM
The estimate for compound 4 equals the measured number at the digits printed, and the stated range covers the measured number.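

In this assay benzyl in place of 3-(dimethylamino)phenoxy gives a 3.5-fold lower number from compound 3 to compound 4 (0.54 log units; beyond the scatter) on the core carrying 5-fluoro-2-methoxyphenyl, the same size as a 3.5-fold lower number from compound 1 to compound 2 (0.54 log units; beyond the scatter) on the core carrying furan-2-yl, and swapping those two groups gives no change at the digits printed from compound 2 to compound 4 (within the scatter) with benzyl in place as well. This shows the step carrying from one of these two cores to the other, on two occurrences only, and does not show that it holds on any further core in the series. Nothing measured here accounts for the step.

Still open, going by these compounds, is whether the step survives with a pyridine ring in place of furan-2-yl, or with a longer chain carrying the amine. Also open, on these data alone, is how an unsubstituted phenoxy or a carboxylic acid at the aromatic carbon would compare.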